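Carbamate Aryl Swap on a Prenylated Pyridinone Core

The source may report more compounds than this note shows. Statements on the series, on what has been measured and on what is new or still open speak of the compounds shown alone.

Measured so far:
compound 1 `CC(C)=CCC/C(C)=C/CC1Cc2c(OCc3ccccc3)cc(=O)n(CCCO)c2CC1(C)C` gives 46.5%
compound 2 `CC(C)=CCC/C(C)=C/COc1cc(=O)n(CCCO)c2c1CC(C/C=C(\C)CCC=C(C)C)C(C)(C)C2` gives 15.8%
compound 3 `COc1cccc(NC(=O)Oc2cc(=O)n(CCCO)c3c2CC(C/C=C(\C)CCC=C(C)C)C(C)(C)C3)c1` gives 47%

All three were tested in a functional assay on PANC-1 cells (Homo sapiens) for inhibition, read by MTT assay, with a stated time of 24 h, tested at 10 uM; a higher number here means more inhibition at the concentration tested (going by the name of the read-out), a lower number less inhibition. Compound 3 shows the highest of the three numbers, but its edge over compound 1 is only a number 0.5 percentage points higher from compound 1 to compound 3 (within the scatter), which lies within the scatter, so the two cannot be ranked against each other; compound 2 sits well apart, with a number 31.2 percentage points higher from compound 2 to compound 3 (beyond the scatter). The other measured step, a number 30.7 percentage points lower from compound 1 to compound 2 (beyond the scatter), likewise changes the group on the oxygen of the aromatic ring.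

Compound 4 `CC(C)=CCC/C(C)=C/CC1Cc2c(OC(=O)Nc3ccc(F)c(F)c3)cc(=O)n(CCCO)c2CC1(C)C` is not yet measured. It keeps the carbamate of compound 3 and changes only the aryl on the amide-type nitrogen: 3,4-difluorophenyl in place of 3-methoxyphenyl on an amide-type nitrogen. Among the compounds with values here, no measured step alters this aryl group; the measured steps vary the group on the ring oxygen, and the one that keeps the carbamate's oxygen intact, a number 0.5 percentage points higher from compound 1 to compound 3 (within the scatter), falls within the scatter. The data therefore give no basis to expect a step beyond the scatter in this assay .

Compound 4 is expected to give about 45%, between 30% and 60%, an estimated step of a number 2 percentage points lower from compound 3 to compound 4 (within the scatter).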

Compound 4, a percentage reported as inhibition, at one concentration (the size of the read-out at that concentration, not a potency): 43.7%
Beside the measured number, compound 4's estimate is 1.3 percentage points above it; the measured number falls inside the stated range.
By their numbers in this assay, from the lowest: compound 2; then compounds 4, 1 and 3 (each within the scatter of the next).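

In this assay, the step at the aryl group on the amide-type nitrogen, 3,4-difluorophenyl in place of 3-methoxyphenyl, is a number 3.3 percentage points lower from compound 3 to compound 4 (within the scatter), so this particular swap leaves the read-out unchanged within the scatter. The second carbamate also stands level with the benzyl group on the ring oxygen, a number 2.8 percentage points lower from compound 1 to compound 4 (within the scatter), and clear of the 3,7-dimethylocta-2,6-dien-1-yl group, a number 27.9 percentage points higher from compound 2 to compound 4 (beyond the scatter), so both carbamates shown behave alike against these two groups. No measurement here explains why the two aryl groups give such similar results.

As far as these compounds go, whether an aryl group carrying an amine or a carboxylic acid, or a simple alkyl chain in place of the aryl group, would shift the number remains open. A single tested concentration also leaves the potency of these compounds unresolved.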